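The compounds below may be only part of what the source reports. "The series", "measured", "known", "first", "only" and "open" are said of these compounds alone.

Measured compounds:
compound 1, `CNC(=O)c1cc(C(=O)N[C@H]2[C@@H]3C[C@H](O)C[C@@H]32)n([C@@H](C)c2cccc(Cl)c2)n1`, 3.7
compound 2, `CNC(=O)c1cc(C(=O)N[C@H]2CC[C@H](O)CC2)n([C@@H](C)c2ccc(Cl)cc2)n1`, 3.7
compound 3, `CNC(=O)c1cc(C(=O)N[C@H]2CC[C@H](O)CC2)c([C@@H](C)c2cccc(C)c2)o1`, 3.3

Of the compounds shown here, three have been measured in a physicochemical assay for lipophilicity; a lower number here means a more polar compound, a higher number a more lipophilic compound. Compound 1 gives 3.7, compound 2 gives 3.7 and compound 3 gives 3.3. Compound 3 stands lowest of the three; compound 1 and compound 2 each lie higher by a gap that is beyond the usual scatter of this assay, so compound 3 is the most polar of the three by this measure.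

Compound 4, `CNC(=O)c1cc(C(=O)N[C@H]2CC[C@H](O)CC2)c([C@@H](C)c2ccc(Cl)cc2)o1`, has not yet been measured. It differs from compound 3 in one place: 4-chlorophenyl in place of 3-methylphenyl on a saturated chain carbon bound to an aromatic carbon and a saturated chain carbon. Within the data shown here, no measured pair shows exactly this exchange, so its effect in this assay cannot be read off directly. Compound 2 also carries a 4-chlorophenyl group, but on a different core, so its value only shows that such a group is compatible with a number near the upper end of this small set.

For the step from compound 3 to compound 4 a small upward move is expected, a number 0.20 log units higher from compound 3 to compound 4 (within the scatter), which may stay within the scatter of repeated measurements. Compound 4 is accordingly estimated at 3.5, with a plausible range from 3.2 to 3.8.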

Compound 4, distribution coefficient: 3.5
Compound 4: middle estimate and measured number agree at the digits printed; the measured number falls inside the stated range.
By their numbers in this assay, from the lowest: compounds 3, 4, 1 and 2 (each within the scatter of the next, the first and the last beyond it).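

Among these compounds, the first matched pair at this position shows that in this assay, 4-chlorophenyl in place of 3-methylphenyl on a saturated chain carbon bound to an aromatic carbon and a saturated chain carbon gives a number 0.20 log units higher from compound 3 to compound 4 (within the scatter). The earlier compounds shown here could not show this, as no two of them differ in one place only; this pair shows that this particular exchange leaves a difference that repeated measurements could not separate from scatter, although one pair on one core sets no rule for the position. Nothing available explains this small step, and the exchange alters both the group on the ring and where it sits, so the pair cannot divide the step between those two parts.

Among the compounds shown here, still open is whether the same exchange on the core of compound 1 or compound 2 would give a similar step, as no matched pair exists there. Also open, as far as these compounds go, is how far this number would move with a more different group at this position, such as a phenyl ring carrying an amine or a carboxylic acid, in place of the chlorine or methyl.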